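This account rests on a few compounds, and the source may have more. Where it says the series, first, only, none or still open, it means among the compounds named here.

Measured compounds:
Compound 1, `Cc1cc(=O)oc2cc(SCc3ccccn3)ccc12`: in a functional assay on DU-145 cells (Homo sapiens) for antiproliferative activity, read by sulforhodamine B assay, with a stated time of 72 h (on this read-out higher numbers stand for weaker inhibition of growth and lower numbers for stronger inhibition of growth), compound 1 gives > 35200 nM, which is a limit of the assay and not a number.
Compound 2, `Cc1cc(=O)oc2cc(SCc3cccnc3)ccc12`: in this assay compound 2 gives > 35200 nM, which is likewise a limit of the assay and not a number.

Compound 2 therefore stands at the limit in this assay; its inhibition of growth was too weak for a number to be read. Among the compounds with values here, the only measured step, a step that the two limits leave unreadable from compound 1 to compound 2, has no readable size, as the limit of > 35200 nM in this assay, at which 2 of the 2 values shown sit, shows.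

Compound 3, `Cc1cc(=O)oc2cc(SCc3ccncc3)ccc12`, is the third member of this series, differing from compound 2 by pyridin-4-yl in place of pyridin-3-yl on a saturated chain carbon bound to a sulfur. Within the data shown here, the one measured step that bears on this kind of change, the move of the ring nitrogen from compound 1 to compound 2, has no readable size, so the expectation rests on the limits alone. A step of no size beyond the scatter is expected in this assay, and compound 3 is expected to remain at the limit as well. The step expected from compound 2 to compound 3 is a step that the limit leaves unreadable from compound 2 to compound 3. Compound 3 is estimated at 50000 nM, within a range from 20000 nM to 200000 nM.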

Compound 3, concentration for 50% growth inhibition: > 35200 nM
Compound 3: no number, only a limit (the forecaster's own chance of this, stated with the estimate: 85%); the middle value does not contradict the limit.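

In this assay compound 3 gives > 35200 nM, which is a limit of the assay and not a number. Within the data shown here, no step among compound 1, compound 2 and compound 3 can be read, because all three sit at one limit: the limit of > 35200 nM in this assay, at which 3 of the 3 values shown sit. The compounds shown leave open whether pyridin-2-yl, pyridin-3-yl and pyridin-4-yl differ in their inhibition of growth at all.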